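Swapping the aryl group on the ring nitrogen

The compounds below may be only part of what the source reports. "The series", "measured", "known", "first", "only" and "open" are said of these compounds alone.

Measured in a functional assay on K562 cells (Homo sapiens) for antiproliferative activity, read by fluorescence, with a stated time of 3 days; on this read-out higher numbers stand for weaker inhibition and lower numbers for stronger inhibition:
Compound 1 `Clc1ccccc1Nc1nc(SCCc2ccccc2)nc2[nH]ncc12`: 19900 nM
Compound 2 `CCCCCSc1nc(Nc2ccccc2Cl)c2cn[nH]c2n1`: 19900 nM

Going by the values given here, only two compounds have been measured so far, and they stand level. Compound 1 gives 19900 nM and compound 2 gives 19900 nM, and the step of no change at the digits printed from compound 1 to compound 2 (within the scatter) shows propyl in place of phenyl on a saturated chain carbon.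

Compound 3 `O=[N+]([O-])c1cccc(Nc2nc(SCCc3ccccc3)nc3[nH]ncc23)c1` keeps the shared core and the phenyl-ended chain on sulfur of compound 1, and differs elsewhere: 3-nitrophenyl in place of 2-chlorophenyl on a nitrogen on an aromatic ring. In words, 3-nitrophenyl takes the place of 2-chlorophenyl on a nitrogen on an aromatic ring.

Among the compounds with values here, the one measured step bears on this only loosely, since it lies in the chain on sulfur and not at this nitrogen. Within the data shown here, no measured pair shows what a change at this nitrogen does, so the data favour neither direction in this assay. The expectation therefore starts from compound 1 at 19900 nM and foresees no step beyond the scatter, with wide uncertainty.

The expected change is a 1.3-fold lower number from compound 1 to compound 3 (0.12 log units; within the scatter). For compound 3 the estimated value is 15000 nM, with an expected range from 5000 nM to 45000 nM.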

Compound 3, half-maximal inhibitory concentration: 19900 nM
Estimate against measurement, compound 3: 1.3-fold (0.12 log units) below, and the stated range covers the measured number.
By their numbers in this assay, from the lowest: compounds 1, 2 and 3 (each within the scatter of the next).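

In this assay the exchange of 2-chlorophenyl for 3-nitrophenyl on the nitrogen on an aromatic ring gives no change at the digits printed from compound 1 to compound 3 (within the scatter) and so provides this position with a measured step of its own, where the earlier pair spoke only to the chain on sulfur. The exchange removes the chlorine and brings in a group with hydrogen-bond acceptors where 2-chlorophenyl has none, yet compound 1 and compound 3 stand level at the digits printed, so this one difference in the aryl group on the nitrogen leaves no mark on the read-out. Nothing among the available data offers an explanation for this result.

From the compounds shown here alone, a single exchange at this nitrogen cannot show how far the position would accept other groups, so it stays open whether an amine or a carboxylic acid on the phenyl ring, or a plain alkyl chain in place of the aryl group, would produce a step beyond the scatter. Going by these compounds, it also stays open whether 3-nitrophenyl would give the same picture when paired with the chain on sulfur of compound 2.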